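Cytotoxicity notes: aryl swap at the saturated ring carbon

The source may report more compounds than this note shows. Statements on the series, on what has been measured and on what is new or still open speak of the compounds shown alone.

The series shares one core and differs in the aryl group on a saturated ring carbon. Compound 1 `COc1cc(N2C(N)=C(C#N)C(c3ccccc3O)C3=C2CC(C)(C)CC3=O)cc(OC)c1OC` carries 2-hydroxyphenyl there; in a functional assay on Ehrlich cells (Mus musculus) for cytotoxicity, tested at 50 ug/mL (on this read-out lower numbers stand for a weaker effect and higher numbers for a stronger effect at the one concentration tested), compound 1 gives 2%. Compound 2 `COc1ccccc1C1C(C#N)=C(N)N(c2cc(OC)c(OC)c(OC)c2)C2=C1C(=O)CC(C)(C)C2` carries 2-methoxyphenyl, and in this assay compound 2 gives 70%. Compound 3 `COc1cc(N2C(N)=C(C#N)C(c3ccc(C)cc3)C3=C2CC(C)(C)CC3=O)cc(OC)c1OC` carries 4-methylphenyl, and in this assay compound 3 gives 60%. Among the three numbers compound 3 stands second highest: its nearest neighbour is compound 2, a gap within the scatter, and its furthest is compound 1, a gap beyond the scatter. The measured steps are a number 68 percentage points higher from compound 1 to compound 2 (beyond the scatter), a number 58 percentage points higher from compound 1 to compound 3 (beyond the scatter) and a number 10 percentage points lower from compound 2 to compound 3 (within the scatter).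

Compound 4 `COc1cc(N2C(N)=C(C#N)C(c3ccccc3Cl)C3=C2CC(C)(C)CC3=O)cc(OC)c1OC` is not yet measured. It differs from compound 3 as follows: 2-chlorophenyl in place of 4-methylphenyl on a saturated ring carbon. Going by the values given here, the steps that bear on this are the two aryl swaps on the same carbon, one large, one within the scatter. Nothing here tells how 2-chlorophenyl behaves. The expectation is therefore a step of a number 5 percentage points lower from compound 3 to compound 4 (within the scatter), within the scatter, so that compound 4 is estimated at 55%, with a range from 25% to 80%.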

Compound 4, a percentage reported as activity, at one concentration (the size of the read-out at that concentration, not a potency): 20%
Estimate against measurement, compound 4: 35 percentage points above; the whole stated range lies above it.
By their numbers in this assay, from the lowest: compound 1; then compound 4; then compounds 3 and 2 (each within the scatter of the next).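

In this assay, swapping the aryl group on the saturated ring carbon gives a number 40 percentage points lower from compound 3 to compound 4 (beyond the scatter) and a number 50 percentage points lower from compound 2 to compound 4 (beyond the scatter), while the comparison with the 2-hydroxyphenyl compound gives a number 18 percentage points higher from compound 1 to compound 4 (beyond the scatter), so compound 4 stands apart from all three earlier compounds. Hydroxy, chloro and methoxy on the same aromatic carbon thus give three separate levels, which shows that the read-out depends on which group sits there and not merely on that carbon being substituted. Nothing measured here accounts for these differences.

The compounds shown leave open whether the level of compound 4 follows from chloro itself or from its place on the phenyl ring, as 4-chlorophenyl would tell. As far as these compounds go, how 2-aminophenyl or 2-methylphenyl would read at this carbon also stays open.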